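The source may report more compounds than this note shows. Statements on the series, on what has been measured and on what is new or still open speak of the compounds shown alone.

Of the compounds shown here, three sharing one core have been measured in an assay on isolated protein for inhibition of cathepsin S (Homo sapiens), read by fluorescence, with a stated time of 20 min; on this read-out higher numbers stand for weaker inhibition and lower numbers for stronger inhibition. Compound 2 `N#CC1(NC(=O)[C@@H]2C[C@@H](S(=O)(=O)c3ccccc3)C[C@H]2C(=O)N2CC3CCC(C2)O3)CC1` gives 1 nM, compound 1 `CC(C)(C#N)NC(=O)[C@@H]1C[C@@H](S(=O)(=O)c2ccccc2)C[C@H]1C(=O)N1CCOCC1` gives 3 nM, and compound 3 `N#CC1(NC(=O)[C@@H]2C[C@@H](S(=O)(=O)c3ccccc3)C[C@H]2C(=O)N2CCNCC2)CC1` gives 11 nM. Compound 3 thus stands with the highest number of the three: compound 1 sits closest to it, compound 2 furthest.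

Compound 4 `N#CC1(NC(=O)[C@@H]2C[C@@H](S(=O)(=O)c3ccccc3)C[C@H]2C(=O)N2CCC2)CC1` has not yet been measured. It differs from compound 3 by one change: azetidin-1-yl in place of piperazin-1-yl on a carbonyl carbon. Among the measured compounds shown here, the only single step that touches the same carbonyl is an 11-fold higher number from compound 2 to compound 3 (1.04 log units; beyond the scatter), and that step also exchanged one ring amide for another. The values of compound 1 and compound 3 show that a ring on this carbonyl without a hydrogen-bond donor can go with a lower number than the piperazin-1-yl ring.

On that basis compound 4 is expected to give a number somewhat lower than compound 3, a step of a 2.8-fold lower number from compound 3 to compound 4 (0.44 log units; beyond the scatter) in this assay. The estimate for compound 4 is 4 nM, with a range from 1.5 nM to 12 nM.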

Compound 4, half-maximal inhibitory concentration: 10 nM
For compound 4 the middle estimate is 2.5-fold (0.40 log units) below the measured one; the measured number falls inside the stated range.
By their numbers in this assay, from the lowest: compound 2; then compound 1; then compounds 4 and 3 (each within the scatter of the next).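

On the shared core, in this assay, azetidin-1-yl in place of piperazin-1-yl on a carbonyl carbon leaves the two compounds within the scatter (a 1.1-fold lower number from compound 3 to compound 4 (0.04 log units; within the scatter)), although the entering group has fewer heavy atoms and no hydrogen-bond donor. The step from the group on compound 2 to azetidin-1-yl (a 10-fold higher number from compound 2 to compound 4 (1.00 log units; beyond the scatter)) is of much the same size as the one to piperazin-1-yl (an 11-fold higher number from compound 2 to compound 3 (1.04 log units; beyond the scatter)), so the group on compound 2 goes with a lower number than either of these rings. Nothing measured here accounts for this pattern.

From the compounds shown here alone, it remains open whether a morpholine ring on the cyanocyclopropyl core of compound 2 would stay close to compound 2 or fall with compound 3 and compound 4. The same question stands for an open-chain dimethylamino group on this carbonyl carbon.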